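Swapping the 2-(pyrrolidin-1-yl)ethyl group of compound 2 for a triazole

A few compounds are considered here, and "the series" means these few. Any claim that something is new, unique, unknown or untested is made for them only; others in the source may bear on it.

Of the compounds shown here, two sharing one core have so far been measured in a functional assay on COLO 205 cells (Homo sapiens) for inhibition; a higher number here means a weaker inhibitor of growth, a lower number a stronger inhibitor of growth. Compound 1 `C=C1C(=O)O[C@H]2[C@H]1CC/C(COC(=O)N1CCC(F)(F)CC1)=C\CC[C@@]1(C)O[C@@H]21` gives 2060 nM, and compound 2 `C=C1C(=O)O[C@H]2[C@H]1CC/C(COC(=O)NCCN1CCCC1)=C\CC[C@@]1(C)O[C@@H]21` gives 4780 nM, the higher of the two numbers and so the weaker inhibitor of growth. Compound 3 `C=C1C(=O)O[C@H]2[C@H]1CC/C(COC(=O)Nc1n[nH]c(SC)n1)=C\CC[C@@]1(C)O[C@@H]21` has not yet been measured. It keeps the core of compound 2 and differs in one group: 5-(methylsulfanyl)-1H-1,2,4-triazol-3-yl in place of 2-(pyrrolidin-1-yl)ethyl on an amide-type nitrogen. In words, 5-(methylsulfanyl)-1H-1,2,4-triazol-3-yl stands in place of 2-(pyrrolidin-1-yl)ethyl on an amide-type nitrogen. For the measured compounds named here, only one measured step bears on this change, a 2.3-fold higher number from compound 1 to compound 2 (0.37 log units; beyond the scatter). That step is modest, though beyond the scatter, and it alters the group on the same carbonyl carbon. Two compounds establish no trend, and neither carries an aromatic ring there, so the direction is uncertain. A small step is expected, with a slight lean towards a lower number. The expected step is a 1.6-fold lower number from compound 2 to compound 3 (0.20 log units; within the scatter). The estimate for compound 3 is 3000 nM, with an expected range of 1200 nM to 7500 nM.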

Compound 3, concentration for 50% growth inhibition: 1790 nM
Compound 3: middle estimate off by 1.7-fold (0.22 log units), on the high side; measured number inside the range.
By their numbers in this assay, from the lowest: compounds 3 and 1 (each within the scatter of the next); then compound 2.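

In this assay, placing 5-(methylsulfanyl)-1H-1,2,4-triazol-3-yl on the amide-type nitrogen gives a 2.7-fold lower number from compound 2 to compound 3 (0.43 log units; beyond the scatter), a modest step beyond the scatter, so an aromatic ring with 3 hetero atoms is accommodated at this position and goes with a stronger inhibition of growth than 2-(pyrrolidin-1-yl)ethyl. On the carbonyl carbon, (5-(methylsulfanyl)-1H-1,2,4-triazol-3-yl)amino in place of 4,4-difluoropiperidin-1-yl gives a 1.2-fold lower number from compound 1 to compound 3 (0.06 log units; within the scatter), which lies within the scatter, so two quite different groups cannot be told apart here and compound 2 alone stands apart from them. No measurement among those shown accounts for either step.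

As far as these compounds go, it remains open whether the step to compound 3 belongs to the triazole ring or to its methylsulfanyl group, a question that an unsubstituted 1H-1,2,4-triazol-3-yl or a methoxy-bearing triazole would address. Also open, from the compounds shown here alone, is whether the ring nitrogen of 2-(pyrrolidin-1-yl)ethyl goes with the higher number of compound 2, which a 2-cyclopentylethyl group, with carbon in that place, would test.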